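A few compounds are considered here, and "the series" means these few. Any claim that something is new, unique, unknown or untested is made for them only; others in the source may bear on it.

Compound 1 `CC(=O)c1cccc(CC[C@H](SC[C@@H](C)C(=O)O)c2cccc(/C=C/c3ccc4ccc(Cl)cc4n3)c2)c1` gives 5.9 nM in an assay on membranes from lung for inhibition of cysteinyl leukotriene receptor 1 (Cavia porcellus); on this read-out higher numbers stand for weaker inhibition and lower numbers for stronger inhibition. Within the data shown here, compound 2 `C[C@H](CS[C@@H](CCc1cccc(CO)c1)c1cccc(/C=C/c2ccc3ccc(Cl)cc3n2)c1)C(=O)O` gives 2.1 nM in this assay and so holds the lower of the two numbers known; the only measured step, a 2.8-fold lower number from compound 1 to compound 2 (0.45 log units; beyond the scatter), came from putting hydroxymethyl in place of acetyl. Compound 3 `COC(=O)c1cccc(CC[C@H](SC[C@@H](C)C(=O)O)c2cccc(/C=C/c3ccc4ccc(Cl)cc4n3)c2)c1` differs from compound 2 by methoxycarbonyl in place of hydroxymethyl on an aromatic carbon. Among the measured compounds shown here, this change removes the hydroxymethyl again and brings in another carbonyl-carrying group, so it runs against the direction of the one step measured; compound 3 is therefore expected to show a rise of a 2.4-fold higher number from compound 2 to compound 3 (0.38 log units; beyond the scatter), to an estimated 5 nM, with a range from 2 nM to 13 nM.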

Compound 3, half-maximal inhibitory concentration: 7 nM
Compound 3: the middle estimate sits 1.4-fold (0.15 log units) below what was measured, and the stated range covers the measured number.
By their numbers in this assay, from the lowest: compound 2; then compounds 1 and 3 (each within the scatter of the next).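

In this assay, methoxycarbonyl in place of hydroxymethyl on this aromatic carbon gives a 3.3-fold higher number from compound 2 to compound 3 (0.52 log units; beyond the scatter), while methoxy in place of methyl on the carbonyl carbon gives a 1.2-fold higher number from compound 1 to compound 3 (0.07 log units; within the scatter). Thus, the two carbonyl-bearing groups, acetyl and methoxycarbonyl, cannot be told apart here, and among these three compounds only hydroxymethyl, in compound 2, stands apart with the lowest number. No measurement at hand explains this difference.

On these data alone, it remains open whether the hydroxyl hydrogen matters, which a methoxymethyl group could test. As far as these compounds go, how a carboxylic acid, an amine or a longer hydroxyalkyl chain would read at this position is also open.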